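Swapping a Ring Group Without a Clearance Baseline

A few compounds are considered here, and "the series" means these few. Any claim that something is new, unique, unknown or untested is made for them only; others in the source may bear on it.

- compound 1 `O=C1c2ccccc2CN1c1cnc(NCc2c(F)ccc3c2CCO3)n2cnnc12`: "not determined" (no result reported)
- compound 2 `CNC(=O)c1ccc(-c2cnc(NCc3c(F)ccc4c3CCO4)c3cn[nH]c(=O)c23)c(C)n1`: 24 mL/min/kg

In an ADME assay on the whole organism (Rattus norvegicus) for pharmacokinetics (a lower number here means slower removal, a higher number faster removal of the compound), compound 1 has the entry "not determined" (no result reported), so it offers no number to start from. Going by the values given here, the only number available is that of compound 2, at 24 mL/min/kg.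

The next structure, compound 3 `O=C1CC2(CC2)CN1c1cnc(NCc2c(F)ccc3c2CCO3)n2cnnc12`, has yet to be measured. Its change is this: a group of 8 heavy atoms (6 carbon, 1 nitrogen, 1 oxygen; one three-membered non-aromatic ring of carbon only, one five-membered non-aromatic ring with 1 hetero atom) in place of a group of 10 heavy atoms (8 carbon, 1 nitrogen, 1 oxygen; one five-membered non-aromatic ring with 1 hetero atom, one six-membered aromatic ring of carbon only), on an aromatic carbon. Both groups hold a five-membered non-aromatic ring with 1 hetero atom, while the six-membered aromatic ring of carbon only gives way to a three-membered non-aromatic ring of carbon only.

Among the compounds with values here, with no measured starting point, the data support no direction for this step in this assay, and no shift beyond the usual scatter is expected. The expectation therefore leans on compound 2 at 24 mL/min/kg, a single and loose anchor. For compound 3 the estimated clearance is 27 mL/min/kg, with an expected range of 10 mL/min/kg to 65 mL/min/kg.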

Compound 3, clearance: 23 mL/min/kg
Compound 3: the middle estimate sits 1.2-fold (0.07 log units) above what was measured, and the stated range covers the measured number.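

In this assay, going by these compounds alone, compound 3 gives 23 mL/min/kg while compound 1 carries the entry "not determined" (no result reported) and so no step between these two compounds can be read. The compounds shown leave open how the change between compound 1 and compound 3 bears on clearance. No supporting evidence bears on this result.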